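The compounds below may be only part of what the source reports. "The series", "measured", "known", "first", "only" and "open" are said of these compounds alone.

Compound 1 `COc1ccc(C(O)(C/C=C\c2ccccc2)c2cccc3ccccc23)c(OC)c1OC`: in a functional assay on MCF7 cells (Homo sapiens) for inhibition, read by sulforhodamine B assay, with a stated time of 48 h (a lower number here means a stronger inhibitor, a higher number a weaker inhibitor), compound 1 gives 10200 nM.
Compound 2 `CCOC(=O)C(C)C(O)(c1ccc(OC)c(OC)c1OC)c1cccc2ccccc12`: in this assay compound 2 gives only a limit, > 20000 nM, and no number.

Compound 2 therefore sits at the edge of what this assay can report, the only one of the two measured compounds to do so (the limit of > 20000 nM in this assay, at which 1 of the 2 values shown sits). Compound 3 `COc1ccc(C(O)(Cc2ccccc2)c2cccc3ccccc23)c(OC)c1OC` differs from it by benzyl in place of 1-(ethoxycarbonyl)ethyl on a saturated chain carbon bound to two aromatic carbons and an oxygen on a saturated carbon. For the measured compounds named here, the one measured step at this position, an at least 1.9-fold higher number from compound 1 to compound 2 (0.29 log units; that floor lies within the scatter), runs the opposite way, from 3-phenylprop-2-en-1-yl to 1-(ethoxycarbonyl)ethyl, and made the number larger. Benzyl, like 3-phenylprop-2-en-1-yl, carries an aromatic ring, so the change is expected to undo most of that loss. Because compound 1 gives 10200 nM in this assay, compound 3 is expected to show a step of an at least 2.0-fold lower number from compound 2 to compound 3 (0.30 log units; that floor lies within the scatter). Compound 3 is thus estimated at 10000 nM, with a likely range from 4000 nM to 25000 nM.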

Compound 3, half-maximal inhibitory concentration: 10600 nM
For compound 3 the middle estimate is 1.1-fold (0.03 log units) below the measured one; the range from low to high includes it.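

Replacing 2-phenylethenyl with phenyl, two bonds along the chain from the two aromatic carbons, leaves the reading in this assay unchanged, with a 1.0-fold higher number from compound 1 to compound 3 (0.02 log units; within the scatter); the shorter benzyl group and the longer 3-phenylprop-2-en-1-yl group cannot be told apart here. Among these three compounds, the two with an aromatic ring in this side chain give measured numbers, whereas compound 2, which has no ring there, gives only a limit. Benzyl in place of 1-(ethoxycarbonyl)ethyl gives an at least 1.8-fold lower number from compound 2 to compound 3 (0.27 log units; that floor lies within the scatter), and this size is only a floor, with the true gap unknown: the limit of > 20000 nM in this assay, at which 1 of the 3 values shown sits.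

From the compounds shown here alone, what an amine, a carboxylic acid or a plain longer carbon chain would do at this position stays open. So does the effect of a fluorine or methoxy group on the ring of the benzyl group.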